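The compounds below may be only part of what the source reports. "The series", "measured", "known", "first", "only" and "open" are said of these compounds alone.

Measured compounds in this series:
- compound 1, `CC(=O)NN=C1C(Cl)=C(Cl)C(Cl)=C1Cl`: "not determined" (no result reported)
- compound 2, `O=C(c1ccccc1)N(N=C1C(Cl)=C(Cl)C(Cl)=C1Cl)C(=O)c1ccccc1`: 2000 nM
- compound 3, `CN(C)N=C1C(Cl)=C(Cl)C(Cl)=C1Cl`: > 3000 nM

In a functional assay on MM1.S cells (Homo sapiens) for cytotoxicity, read by MTT assay, with a stated time of 48 h (on this read-out higher numbers stand for weaker inhibition and lower numbers for stronger inhibition), compound 1 has no number of its own, so it cannot be placed against the others. In this assay compound 2 gives 2000 nM. In this assay compound 3 gives only a limit, > 3000 nM. One further point is worth keeping in view: the limit of > 3000 nM in this assay, at which 1 of the 3 values shown sits. What the two measured values show is that neither compound 2 nor compound 3 reaches far into the potent range, and that compound 3 sits at the edge of what the assay reports.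

Compound 4, `CC(C)(C)C(=O)NN=C1C(Cl)=C(Cl)C(Cl)=C1Cl`, is not yet measured. It differs from compound 1 in one place: tert-butyl in place of methyl on a carbonyl carbon. Going by the values given here, no measured pair in this set shares that change, so no step size can be read off for it. Both measured neighbours of this core sit weak, and compound 1 itself carries no number, so the expectation for compound 4 is set near them rather than on any trend. Compound 4 is expected to give about 3000 nM, with a range of 800 nM to 9000 nM, and a fair chance that only a limit is reported.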

Compound 4, half-maximal inhibitory concentration: 2000 nM
Beside the measured number, compound 4's estimate is 1.5-fold (0.18 log units) above it, within the range that was stated.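

Going by these compounds alone, compound 1 has no number of its own in this assay, so no step from it to compound 4 can be read. Still open is whether tert-butyl in place of methyl on a carbonyl carbon shifts the read-out at all, and how far the series extends past the one value that is only a limit: the limit of > 3000 nM in this assay, at which 1 of the 4 values shown sits.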